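Extending the ether chain on the shared core of compound 3

The compounds below may be only part of what the source reports. "The series", "measured", "known", "first", "only" and "open" are said of these compounds alone.

Compound 3 `CCOc1c(Br)cc(/C=C2\CCC/C(=C\c3cccc([N+](=O)[O-])c3)C2=O)cc1OC` carries the highest number of the three measured compounds in a functional assay on MCF7 cells (Homo sapiens) for cytotoxicity, read by MTT assay (a higher number here means a weaker inhibitor, a lower number a stronger inhibitor), with a reading of 24.9 ug/mL. Its closest companion is compound 2 `COc1cc(/C=C2\CCC/C(=C\c3cccc([N+](=O)[O-])c3)C2=O)cc(Br)c1OC`, which in this assay gives 4.72 ug/mL, while compound 1 `CCCOc1c(Br)cc(/C=C2\CCC/C(=C\c3ccccc3[N+](=O)[O-])C2=O)cc1OC` stands furthest away with 4.14 ug/mL in the same assay. The move to compound 4 `CCCOc1c(Br)cc(/C=C2\CCC/C(=C\c3cccc([N+](=O)[O-])c3)C2=O)cc1OC` is methyl in place of hydrogen on a saturated chain carbon, two bonds along the chain from an oxygen on an aromatic ring, so that, read one bond further out, the ethoxy becomes a propoxy. Among the measured compounds shown here, only one measured step touches this chain: a 5.3-fold higher number from compound 2 to compound 3 (0.72 log units; beyond the scatter), and it ran towards a weaker inhibitor. Compound 1, which already carries the propoxy chain, shows a low number, but it differs from compound 4 in where the nitro group sits, so its value is only an indirect pointer. The account therefore expects the step of a 2.5-fold lower number from compound 3 to compound 4 (0.40 log units; beyond the scatter) from compound 3 to compound 4 to be modest and uncertain in direction. For compound 4 the estimate in this assay is 10 ug/mL, within a range from 3 ug/mL to 35 ug/mL.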

Compound 4, half-maximal inhibitory concentration: 0.85 ug/mL
Compound 4: middle estimate off by 12-fold (1.07 log units), on the high side, outside the stated range (below it).
By their numbers in this assay, from the lowest: compound 4; then compounds 1 and 2 (each within the scatter of the next); then compound 3.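

In this assay, this chain position does not move in one direction: lengthening the chain gives a 5.3-fold higher number from compound 2 to compound 3 (0.72 log units; beyond the scatter), yet the ethoxy to propoxy change gives a 29-fold lower number from compound 3 to compound 4 (1.47 log units; beyond the scatter), so a single added methyl on this saturated chain carbon reverses the earlier step and goes well past it. The propoxy compound also improves on the starting chain, with a 5.6-fold lower number from compound 2 to compound 4 (0.74 log units; beyond the scatter), which leaves the ethoxy chain of compound 3 as the exception within this series of three, not the midpoint of a trend. With the propoxy chain held fixed, the nitro group matters as well: 3-nitrophenyl in place of 2-nitrophenyl gives a 4.9-fold lower number from compound 1 to compound 4 (0.69 log units; beyond the scatter), so the low number of compound 4 depends on both places together. Nothing available accounts for the reversal along the chain.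

The compounds shown leave open whether the trend continues to a longer chain such as butoxy, or whether a branched isopropoxy group or a chain ending in an amine keeps the low number. They also leave open whether the ethoxy chain gives the same high number when paired with 2-nitrophenyl.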